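The source may report more compounds than this note shows. Statements on the series, on what has been measured and on what is new or still open speak of the compounds shown alone.

In a functional assay on HL-60 cells (Homo sapiens) for inhibition, read by CCK-8 assay, with a stated time of 48 h (on this read-out higher numbers stand for weaker inhibition and lower numbers for stronger inhibition), compound 3 (`O=[N+]([O-])c1ccc(Oc2ccccc2-c2ccc(S(=O)(=O)NCCNC(=S)Nc3cc(C(F)(F)F)cc(C(F)(F)F)c3)s2)cc1`) gives 7200 nM as the highest of the three numbers, with compound 1 (`O=S(=O)(NCCNC(=S)Nc1cc(C(F)(F)F)cc(C(F)(F)F)c1)c1ccc(-c2ccccc2O[C@H]2CC[C@@H](O)CC2)s1`) at 2600 nM and compound 2 (`O=S(=O)(NCCNC(=S)Nc1cc(C(F)(F)F)cc(C(F)(F)F)c1)c1ccc(-c2ccccc2OCc2ccccc2)s1`) at 2100 nM as the lower two. Those two do not separate (a 1.2-fold lower number from compound 1 to compound 2 (0.09 log units; within the scatter)). Compound 4 (`O=S(=O)(NCCNC(=S)Nc1cc(C(F)(F)F)cc(C(F)(F)F)c1)c1ccc(-c2ccccc2Oc2ccc(O)c(O)c2)s1`) has 3,4-dihydroxyphenyl in place of 4-nitrophenyl on an oxygen on an aromatic ring. Among the measured compounds shown here, two steps bear on this: a 2.8-fold higher number from compound 1 to compound 3 (0.44 log units; beyond the scatter) and a 3.4-fold higher number from compound 2 to compound 3 (0.54 log units; beyond the scatter) are both modest and both end at the 4-nitrophenyl group. For the measured compounds named here, no measured compound carries 3,4-dihydroxyphenyl, so only a modest shift to a lower number is expected. The expected step is a 2.4-fold lower number from compound 3 to compound 4 (0.38 log units; beyond the scatter) in size. In this assay compound 4 is estimated at 3000 nM with an expected range from 1000 nM to 8000 nM for the measurement.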

Compound 4, half-maximal inhibitory concentration: 18300 nM
Compound 4: middle estimate off by 6.1-fold (0.79 log units), on the low side, outside the stated range (above it).
By their numbers in this assay, from the lowest: compounds 2 and 1 (each within the scatter of the next); then compound 3; then compound 4.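

In this assay the aromatic ring on this oxygen tolerates substitution poorly: 3,4-dihydroxyphenyl raises the number further than 4-nitrophenyl did (a 2.5-fold higher number from compound 3 to compound 4 (0.41 log units; beyond the scatter)). Against the non-aryl groups the gap widens (an 8.7-fold higher number from compound 2 to compound 4 (0.94 log units; beyond the scatter); a 7.0-fold higher number from compound 1 to compound 4 (0.85 log units; beyond the scatter)), so both compounds with a ring bonded directly to this oxygen, compound 3 and compound 4, stand above compound 1 and compound 2, with none going against this among the four. No evidence on the cause of this rise is at hand. A plain phenyl or 4-aminophenyl on this oxygen would help show whether the ring itself or its substituents set the level.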